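The source may hold more compounds than are shown below. What is called first, only, known or untested is meant among the compounds shown, and "the series" means these compounds.

Notes on the series. In a functional assay on the whole organism with Rattus norvegicus as the target (a lower number here means that less compound is needed, a higher number that more compound is needed for the effect), compound 1 `Nc1ccc2nc(N)sc2c1` gives > 10 mg/kg, which is a limit of the assay and not a number. Compound 2 `Nc1nc2cc(OC(F)(F)F)ccc2s1` likewise gives in this assay > 10 mg/kg, again a limit rather than a number. For the measured compounds named here, compound 3 `CCN(CC)C(=O)Cn1c(=N)sc2cc(OC(F)(F)F)ccc21` is the one compound with a measured number: in this assay compound 3 gives 9 mg/kg. Compound 3 therefore stands alone on the numbers shown. Going by the values given here, the other two values sit at the limit of > 10 mg/kg in this assay, at which 2 of the 3 values shown sit, so no step between measured compounds can be sized. Compound 4 `C[S+]([O-])CCCn1c(=N)sc2cc(OC(F)(F)F)ccc21` differs from compound 3 as follows: a group of 5 heavy atoms (3 carbon, 1 oxygen, 1 sulfur; no ring) in place of a group of 7 heavy atoms (5 carbon, 1 nitrogen, 1 oxygen; no ring), on a saturated chain carbon bound to an aromatic nitrogen. Among the compounds with values here, no measured step speaks to a change of this kind, so in this assay no shift beyond the scatter is expected from compound 3 to compound 4. The step is expected to be no change at the digits printed from compound 3 to compound 4 (within the scatter). For compound 4 in this assay the estimate is 9 mg/kg, within a range from 3 mg/kg to 30 mg/kg. Because compound 3 sits close to the limit of > 10 mg/kg in this assay, at which 2 of the 3 values shown sit, compound 4 is expected to carry a real chance of returning only a limit.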

Compound 4, dose for half-maximal effect: 2.3 mg/kg
The estimate for compound 4 lay 3.9-fold (0.59 log units) above the measured number; the whole stated range lies above it.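

Notes on the result. In this assay, the saturated chain carbon bound to an aromatic nitrogen now proves to be a place where the group changes the read-out: the exchange of diethylcarbamoyl for the group of 5 heavy atoms carrying sulfur and oxygen gives a 3.9-fold lower number from compound 3 to compound 4 (0.59 log units; beyond the scatter). Diethylcarbamoyl is therefore not required at this place for a measured number, and a group without the amide nitrogen does better here. Compound 4 also stands further from the limit of the assay than compound 3 does: the limit of > 10 mg/kg in this assay, at which 2 of the 4 values shown sit.

A single step cannot tell whether the lower number belongs to the sulfur and oxygen unit or to the chain that carries it. As far as these compounds go, a shorter chain, a sulfone or an amine at this place remains open, as does a simple ether chain of similar length.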